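This account rests on a few compounds, and the source may have more. Where it says the series, first, only, none or still open, it means among the compounds named here.

Of the compounds shown here, three built on the shared core have been read in an ADME assay on MDBK cells (Bos taurus) for cytotoxicity, read by MTT assay (on this read-out lower numbers stand for higher toxicity in this test and higher numbers for lower toxicity in this test), so far. Compound 2 (`CCCC1CCCCC1OCCCCCCN1C[C@H](O)[C@@H](O)[C@H](O)[C@H]1CO`) gives 150000 nM in this test, the lower of the two actual numbers available. Compound 3 (`OC[C@@H]1[C@@H](O)[C@H](O)[C@@H](O)CN1CCCc1ccccc1OC1CCCCC1`) gives 420000 nM there, a higher number by a gap beyond the usual scatter of repeat measurements. Compound 1 (`OC[C@@H]1[C@@H](O)[C@H](O)[C@@H](O)CN1CCCCCCOc1ccc(OC(F)(F)F)cc1`) reads > 500000 nM in this assay and this is a limit of the assay, not a number.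

Compound 4 (`OC[C@@H]1[C@@H](O)[C@H](O)[C@@H](O)CN1CCCCCCOc1cc(F)ccc1F`) has not yet been measured. Its change from compound 2 is a group of 8 heavy atoms (6 carbon, 2 fluorine; one six-membered aromatic ring of carbon only) in place of a group of 9 heavy atoms (9 carbon; one six-membered non-aromatic ring of carbon only), on an oxygen on a saturated carbon and the group that enters is 2,5-difluorophenyl, on an oxygen on a saturated carbon. For the measured compounds named here, no two measured compounds differ in only one place, so this swap has no direct precedent. A rise in the number, meaning lower toxicity in this test, is expected from the example of compound 1 with an aromatic ring on its chain oxygen at > 500000 nM as a limit. The expected step of a 2.3-fold higher number from compound 2 to compound 4 (0.37 log units; beyond the scatter) is modest and upward, only just beyond the scatter. Compound 4 is estimated at 350000 nM in this assay with an expected range of 170000 nM to 700000 nM around that figure.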

Compound 4, half-maximal cytotoxic concentration: > 500000 nM
Compound 4 was reported as a limit; the forecaster's own chance of this, stated with the estimate: 45%; at least 1.4-fold (0.15 log units) between middle value and limit.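

Swapping the non-aromatic carbon ring group for 2,5-difluorophenyl, on an oxygen on a saturated carbon, gives the first comparison of two compounds that differ in only one place in this assay, and the swap brings an at least 3.3-fold higher number from compound 2 to compound 4 (0.52 log units; beyond the scatter). Since a higher number here stands for lower toxicity in this test, this position accepts an aromatic ring carrying two fluorines, and the direction of the change is clear even though only its minimum size is known. The full size of the step cannot be read, because compound 4 sits at a limit of the assay rather than at a number: the limit of > 500000 nM in this assay, at which 2 of the 4 values shown sit.

The compounds shown leave open whether the rise in the number comes with the aromatic ring itself or needs the two fluorines, since an unsubstituted phenyl group on that oxygen would be needed to separate the two. They also leave open how the read-out would respond to a ring carrying an amine or a carboxylic acid, or to a longer chain between the shared core and the oxygen.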